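Swapping a Bare Phenyl for a Decorated Aryl Group

This account rests on a few compounds, and the source may have more. Where it says the series, first, only, none or still open, it means among the compounds named here.

Compound 1 `Cn1cc(-c2ccccc2)c2cc(C(=O)NCc3ccc(C(=O)Nc4ccccc4N)cc3)[nH]c2c1=O` is the simplest member of this small set. In a functional assay on MV4-11 cells (Homo sapiens) for antiproliferative activity, read by CCK-8 assay, with a stated time of 72 h (a higher number here means a weaker inhibitor, a lower number a stronger inhibitor), compound 1 gives 230 nM, the highest of the three numbers recorded. Compound 2 `Cn1cc(-c2ccccc2Oc2ccccc2)c2cc(C(=O)NCCCCCC(=O)Nc3ccccc3N)[nH]c2c1=O` gives 70 nM in this assay, and compound 3 `Cn1cc(-c2ccccc2Oc2ccccc2)c2cc(C(=O)NCCCCCCC(=O)NO)[nH]c2c1=O` gives 180 nM. Going by the values given here, the one step that can be isolated runs between these two: a 2.6-fold higher number from compound 2 to compound 3 (0.41 log units; beyond the scatter). That step alters the end of the chain, not the aryl group, so it does not speak to the change examined here. Compound 1 and compound 2 differ in two places at once, the aryl group and the chain, so their values cannot be attributed to the aryl group alone.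

Compound 4 `COc1ccc(C(C)(C)O)cc1-c1cn(C)c(=O)c2[nH]c(C(=O)NCc3ccc(C(=O)Nc4ccccc4N)cc3)cc12` carries the change (5-(1-hydroxy-1-methylethyl)-2-methoxyphenyl in place of phenyl on an aromatic carbon). Among the compounds with values here, no measured pair shows the effect of substituents on this aryl ring, so the direction of any step in this assay is open, and a step of either sign, or none beyond the scatter, is possible. Given that uncertainty, compound 4 is expected to give about 150 nM in this assay, within a range of 40 nM to 600 nM. This estimate corresponds to a step of a 1.5-fold lower number from compound 1 to compound 4 (0.19 log units; within the scatter).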

Compound 4, half-maximal inhibitory concentration: 420 nM
Compound 4: middle estimate off by 2.8-fold (0.45 log units), on the low side; low and high end bracket the measured number.
By their numbers in this assay, from the lowest: compound 2; then compounds 3, 1 and 4 (each within the scatter of the next, the first and the last beyond it).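

Going by these compounds alone, compound 4 gives the first direct reading of what happens at this aromatic carbon when only the aryl group changes: in this assay, placing 5-(1-hydroxy-1-methylethyl)-2-methoxyphenyl where phenyl stood gives a 1.8-fold higher number from compound 1 to compound 4 (0.26 log units; within the scatter). A group of 12 heavy atoms, with 1 hydrogen-bond donor and 2 hydrogen-bond acceptors, thus replaces one of 6 heavy atoms with neither, and this pair of compounds still cannot be told apart in this measurement. Nothing available here offers an explanation for why the number holds within the scatter despite so large a change in the group.

The compounds shown leave open what the methoxy group and the 1-hydroxy-1-methylethyl group each contribute alone, as both enter together in compound 4, and whether the phenoxy group carried by compound 2 would give a different result on the chain of compound 1. As far as these compounds go, it also remains open whether a group of another kind on this aryl ring, such as an amine or a carboxylic acid, would move the number beyond the scatter.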